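The source may report more compounds than this note shows. Statements on the series, on what has been measured and on what is new or still open speak of the compounds shown alone.

Among the compounds with values here, compound 2 `CN1CCC(NC(=O)c2ccncc2Nc2cc(-c3ccc4ccn(C)c4c3)c3nccnc3c2)CC1=O` has the lowest of the two numbers measured so far. In an assay for inhibition of 6-phosphofructo-2-kinase/fructose-2,6-bisphosphatase 3 (Homo sapiens), read by ADP-Glo, with a stated time of 2 h (on this read-out lower numbers stand for stronger inhibition and higher numbers for weaker inhibition), compound 2 gives 41 nM, while compound 1 `Cn1ccc2ccc(-c3cc(Nc4cnccc4C(=O)NCc4cncnc4)cc4nccnc34)cc21` gives 106 nM in this assay. Within the data shown here, the one measured step joining them, a 2.6-fold lower number from compound 1 to compound 2 (0.41 log units; beyond the scatter), comes from swapping a flat aromatic-ring bearing group for a saturated six-membered ring on the amide-type nitrogen.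

Compound 3 `CC(=O)N1CCCC(NC(=O)c2ccncc2Nc2cc(-c3ccc4ccn(C)c4c3)c3nccnc3c2)C1` has not been measured. It differs from compound 2 by 1-acetylpiperidin-3-yl in place of 1-methyl-2-oxopiperidin-4-yl on an amide-type nitrogen. Both groups are six-membered non-aromatic rings with one hetero atom, each carrying one carbonyl and one hydrogen-bond acceptor and no donor; the carbonyl sits inside the ring in compound 2 and on the ring nitrogen in compound 3, and the attachment point moves by one ring position. Among the measured compounds shown here, no measured step covers a change of this kind, since the step from compound 1 to compound 2 compares an aromatic group with a saturated one rather than two saturated rings. A step of a 1.6-fold higher number from compound 2 to compound 3 (0.20 log units; within the scatter) is therefore expected, probably within the scatter. For compound 3 the estimate in this assay is 65 nM, with a range from 25 nM to 200 nM.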

Compound 3, half-maximal inhibitory concentration: 11 nM
For compound 3 the middle estimate is 5.9-fold (0.77 log units) above the measured one, outside the stated range (below it).
By their numbers in this assay, from the lowest: compound 3; then compound 2; then compound 1.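

In this assay, two six-membered non-aromatic rings with the same counts of hydrogen-bond donors and acceptors are not interchangeable on the amide-type nitrogen, as the step (a 3.7-fold lower number from compound 2 to compound 3 (0.57 log units; beyond the scatter)) lies beyond the scatter. The saturated replacement for the (pyrimidin-5-yl)methyl group can therefore gain much more than compound 2 first showed, with the step to 1-acetylpiperidin-3-yl (a 9.6-fold lower number from compound 1 to compound 3 (0.98 log units; beyond the scatter)) larger than the step to 1-methyl-2-oxopiperidin-4-yl (a 2.6-fold lower number from compound 1 to compound 2 (0.41 log units; beyond the scatter)), which makes compound 3 the strongest inhibitor of the three. No supporting measurement is available to explain the difference between these two groups.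

The change from compound 2 to compound 3 alters the place of the carbonyl and the point of attachment together and adds one heavy atom, so these compounds cannot show which of these differences matters. A 1-acetylpiperidin-4-yl group would keep the acetyl while changing the attachment point, and a piperidin-3-yl group with a free ring amine would test whether the acetyl is needed at all.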